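Swapping the Aryl Group on Compound 1

The source may hold more compounds than are shown below. What is called first, only, known or untested is meant among the compounds shown, and "the series" means these compounds.

In a physicochemical assay for lipophilicity, at pH 7.4 (a higher number here means a more lipophilic compound, a lower number a more polar compound), compound 1 `COc1cc(-c2nnc3n2CCCC3c2ccc(Cl)c(Cl)c2)ccc1-c1cnc(C)o1` gives 3.2, the lower of the two numbers available. Compound 2 `COc1cc(-c2nnc3n2CCC=C3c2ccc(Cl)c(Cl)c2)ccc1-c1cnc(C)o1` gives 3.6, a gap beyond the usual scatter of such measurements. Compound 3 `COc1cc(-c2nnc3n2CCCC3c2ccccc2C(F)(F)F)ccc1-c1cnc(C)o1` has not yet been measured. It carries 2-(trifluoromethyl)phenyl in place of the 3,4-dichlorophenyl of compound 1, on a saturated ring carbon (2-(trifluoromethyl)phenyl in place of 3,4-dichlorophenyl on a saturated ring carbon). Within the data shown here, no pair of measured compounds shows an exchange of this kind, so the expectation rests on the structural change alone and remains loose. A small downward step in this assay is expected, one not clearly beyond the scatter. The estimated step is a number 0.30 log units lower from compound 1 to compound 3 (within the scatter). For compound 3 the expected value is 2.9, with an estimated range from 2.5 to 3.3.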

Compound 3, distribution coefficient: 3
Compound 3: the middle estimate sits 0.10 log units below what was measured, within the range that was stated.
By their numbers in this assay, from the lowest: compounds 3 and 1 (each within the scatter of the next); then compound 2.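

With 2-(trifluoromethyl)phenyl in place of 3,4-dichlorophenyl on the saturated ring carbon, this assay gives a number 0.20 log units lower from compound 1 to compound 3 (within the scatter), so the two compounds cannot be told apart by this read-out. This is the first exchange of aryl groups at this position among the compounds shown, and it indicates that an aryl group with a different substitution and two more heavy atoms can stand here without a step beyond the scatter. No measurement at hand offers an explanation for how closely the two aryl groups agree.

Going by these compounds, whether the same holds for a group of another kind on this ring carbon, such as an amine or a carboxylic acid, stays open. Also open, on these data alone, is whether 2-(trifluoromethyl)phenyl would give a comparable step on the core of compound 2.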